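Dimethylamino in Place of tert-Butyl on an Aromatic Carbon

This account rests on a few compounds, and the source may have more. Where it says the series, first, only, none or still open, it means among the compounds named here.

Among the measured compounds shown here, in a functional assay on MCF-10A cells (Homo sapiens) for antiproliferative activity, with a stated time of 48 h (on this read-out higher numbers stand for an effect only at larger amounts of compound and lower numbers for an effect already at smaller amounts), compound 1 `COc1ccc2nc(C)cc(NCc3ccc(C(C)(C)C)cc3)c2c1` gives 7000 nM, the lowest number of the three measured so far. Compound 2 `COc1ccc2nc(C)cc(NCc3ccc(F)cc3F)c2c1` gives 15000 nM, and compound 3 `COc1ccc2nc(C)cc(NCc3ccc(F)c(C(F)(F)F)c3)c2c1` gives 14300 nM. Compound 4 `COc1ccc2nc(C)cc(NCc3ccc(N(C)C)cc3)c2c1` keeps the core of compound 1 but carries dimethylamino in place of tert-butyl on an aromatic carbon, para to a large group (dimethylamino in place of tert-butyl on an aromatic carbon). For the measured compounds named here, no measured pair differs in one place only, so the data offer no direct guide to this change. The expectation rests on the narrow span from compound 1 at 7000 nM to compound 2 at 15000 nM: a modest move in this assay towards a higher number, perhaps none beyond the scatter. The expected step is a 1.6-fold higher number from compound 1 to compound 4 (0.20 log units; within the scatter). Compound 4 is estimated at 11000 nM, within a range of 5000 nM to 25000 nM.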

Compound 4, half-maximal effective concentration: 20000 nM
Estimate against measurement, compound 4: 1.8-fold (0.26 log units) below; the measured number falls inside the stated range.
By their numbers in this assay, from the lowest: compound 1; then compounds 3, 2 and 4 (each within the scatter of the next).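

Among the compounds shown here, this is the first single change that can be read in this assay: dimethylamino in place of tert-butyl on an aromatic carbon gives a 2.9-fold higher number from compound 1 to compound 4 (0.46 log units; beyond the scatter) and thus does not keep the lower number of compound 1 at this position. This single pair shows that the assay responds to the group at this position. Nothing measured here explains the rise.

Going by these compounds, it remains open whether a smaller group such as methyl or a different one such as a carboxylic acid would stay closer to compound 1. On these data alone, a primary amine at this position is equally open.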